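Oxazoline for thiazoline on the sulfonylmethyl arm

This account rests on a few compounds, and the source may have more. Where it says the series, first, only, none or still open, it means among the compounds named here.

Measured so far:
compound 1 `Cc1ccc(-c2c[nH]nc2S(=O)(=O)CC2=NCCS2)cc1` — "not active" (no number reported)
compound 2 `COc1ccc(C2=NOC(c3ccc(C)cc3)C2S(=O)(=O)CC2=NCCO2)cc1` — 65.9%
compound 3 `COc1ccc(C2=NOC(c3ccc(C)cc3)C2S(=O)(=O)CC2=NCCS2)cc1` — 47.5%

The series is followed in a functional assay, tested at 50 ug/mL; on this read-out higher numbers stand for a stronger effect at the one concentration tested and lower numbers for a weaker effect. Compound 3 has the thiazoline arm on its core and gives 47.5%; compound 2 carries the oxazoline arm on the same core and gives 65.9%. The change between them is a group of 5 heavy atoms (3 carbon, 1 nitrogen, 1 oxygen; one five-membered non-aromatic ring with 2 hetero atoms) in place of a group of 5 heavy atoms (3 carbon, 1 nitrogen, 1 sulfur; one five-membered non-aromatic ring with 2 hetero atoms), on a saturated chain carbon bound to a sulfonyl sulfur, and the step it made is a number 18.4 percentage points higher from compound 3 to compound 2 (beyond the scatter).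

Compound 1 sits on a different core and is recorded only as not active in this assay, without a number. The difference between the core of compound 1 and the core of compound 3 is not broken down here.

Compound 4 `Cc1ccc(-c2c[nH]nc2S(=O)(=O)CC2=NCCO2)cc1` has not been measured. It differs from compound 1 by a group of 5 heavy atoms (3 carbon, 1 nitrogen, 1 oxygen; one five-membered non-aromatic ring with 2 hetero atoms) in place of a group of 5 heavy atoms (3 carbon, 1 nitrogen, 1 sulfur; one five-membered non-aromatic ring with 2 hetero atoms), on a saturated chain carbon bound to a sulfonyl sulfur, the same change as that from compound 3 to compound 2, at the same place. On the first core that change was worth a modest gain, beyond the scatter. Whether it carries over to the second core is not known from these compounds, and the starting point there is a compound with no activity reported. Among the compounds with values here, a small gain at best is therefore expected for compound 4, resting on the single earlier step of a number 18.4 percentage points higher from compound 3 to compound 2 (beyond the scatter) and on compound 1 being not active. Compound 4 is estimated at 15% in this assay, with a range from 0% to 40%.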

Compound 4, a percentage reported as activity, at one concentration (the size of the read-out at that concentration, not a potency): 60.7%
Compound 4: middle estimate off by 45.7 percentage points, on the low side, and the stated range ends below it.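

No step can be read between compound 1 and compound 4: in this assay compound 1 is recorded as "not active" (no number reported) and compound 4 gives 60.7% with no number on the other side to set against it. The compounds shown leave open how large the oxygen-for-sulfur ring exchange is on the core of compound 1. No measurement here bears on a cause for this result.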